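Trimming the 4-fluorophenyl of Compound 2 to Methyl

The source may hold more compounds than are shown below. What is called first, only, known or untested is meant among the compounds shown, and "the series" means these compounds.

Compound 1 `CC(C)(C)c1ccc(CN2C(=O)S/C(=C\c3ccc(N)cc3)C2=O)cc1` gives 94000 nM in a functional assay on L1210 cells (Mus musculus) for cytotoxicity, read by cell counting, with a stated time of 2 days; on this read-out higher numbers stand for weaker inhibition and lower numbers for stronger inhibition.
Compound 2 `Nc1ccc(/C=C2\SC(=O)N(Cc3ccc(F)cc3)C2=O)cc1` gives 24000 nM in this assay.
Compound 3 `C=C(Br)C(=O)Nc1ccc(/C=C2\SC(=O)N(Cc3ccc(F)cc3)C2=O)cc1` gives 2200 nM in this assay.

Among these three numbers compound 2 stands second highest, between compound 1 and compound 3. Compound 4 `CCN1C(=O)S/C(=C\c2ccc(N)cc2)C1=O` differs from compound 2 in one place: methyl in place of 4-fluorophenyl on a saturated chain carbon bound to an amide-type nitrogen in a ring. Of the measured steps, only a 3.9-fold lower number from compound 1 to compound 2 (0.59 log units; beyond the scatter) touches the 4-fluorophenyl group, and it was modest; an 11-fold lower number from compound 2 to compound 3 (1.04 log units; beyond the scatter) was large but concerns the other end of the shared core and does not bear on this change. For the measured compounds named here, no measured step removes the aromatic ring outright, so the expectation is uncertain: a moderate rise, meaning weaker inhibition, is expected, a 2.5-fold higher number from compound 2 to compound 4 (0.40 log units; beyond the scatter). Compound 4 is therefore estimated at 60000 nM, within 15000 nM to 250000 nM.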

Compound 4, half-maximal inhibitory concentration: 82000 nM
The estimate for compound 4 lay 1.4-fold (0.14 log units) below the measured number; the measured number falls inside the stated range.
By their numbers in this assay, from the lowest: compound 3; then compound 2; then compounds 4 and 1 (each within the scatter of the next).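

Replacing the 4-fluorophenyl with methyl gives a 3.4-fold higher number from compound 2 to compound 4 (0.53 log units; beyond the scatter). The earlier steps shown here only swapped a group on the aromatic ring, whereas this one removes the ring itself, and the cost is modest rather than a complete loss of the effect on the cells. No measurement shown gives a reason for this step. On these data alone, it remains open whether a longer chain such as butyl, or a cyclohexyl ring, would behave more like 4-fluorophenyl or like methyl at this place. As far as these compounds go, it is also open whether adding the (1-bromoethenyl)carbonyl group to compound 4 would help as much as it does on compound 2.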